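A Chloro Group Added to the Core of Compound 1

The source may hold more compounds than are shown below. What is called first, only, known or untested is meant among the compounds shown, and "the series" means these compounds.

Compound 1 `O=c1oc(Nc2ccccc2I)nc2ccccc12`: 3500 nM
Compound 2 `O=c1oc(Nc2ccccc2Br)nc2ccccc12`: 5100 nM
Compound 3 `CSc1ccccc1Nc1nc2ccccc2c(=O)o1`: reported only as a limit of the assay, > 62500 nM

In an assay on isolated protein for inhibition of complement C1r subcomponent (Homo sapiens) (a lower number here means a stronger inhibitor, a higher number a weaker inhibitor), compound 1 gives the lowest of the two numbers shown; the nearest is a 1.5-fold higher number from compound 1 to compound 2 (0.16 log units; within the scatter), within the scatter. For compound 3 the value is a limit (the limit of > 62500 nM in this assay, at which 1 of the 3 values shown sits). The steps of an at least 17-fold higher number from compound 1 to compound 3 (1.25 log units; beyond the scatter) and an at least 12-fold higher number from compound 2 to compound 3 (1.08 log units; beyond the scatter) are large.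

Compound 4 `O=c1oc(Nc2ccccc2I)nc2ccc(Cl)cc12` differs from compound 1 by chloro in place of hydrogen on an aromatic carbon. Within the data shown here, none of the measured steps touches this part of the shared core; all change the group on the aniline ring. Among the measured compounds shown here, no measured step therefore bears on this change, and no step beyond the scatter is expected in this assay, though with wide uncertainty. Compound 4 is expected to give 3000 nM, within a range from 1000 nM to 10000 nM. The step expected for compound 4 is a 1.2-fold lower number from compound 1 to compound 4 (0.07 log units; within the scatter).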

Compound 4, half-maximal inhibitory concentration: 4000 nM
The estimate for compound 4 lay 1.3-fold (0.12 log units) below the measured number, within the range that was stated.
By their numbers in this assay, from the lowest: compounds 1, 4 and 2 (each within the scatter of the next). At a limit, above all of these: compound 3.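

In this assay, chloro in place of hydrogen gives a 1.1-fold higher number from compound 1 to compound 4 (0.06 log units; within the scatter), the first step shown that touches the shared core rather than the group on the aniline ring. This position, meta to a fused ring and para to a fused ring, thus accepts a chlorine with no shift beyond the scatter. Nothing at hand gives a reason for this outcome.

As far as these compounds go, what an amine or a carboxylic acid would do at this position stays open. So does whether chloro here gives the same result alongside bromo instead of iodo.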